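A few compounds are considered here, and "the series" means these few. Any claim that something is new, unique, unknown or untested is made for them only; others in the source may bear on it.

Compound 1 `CC[C@H](CCn1cncn1)c1ccc(C)cc1` carries a triazole on a short chain, an ethyl group and a methyl-bearing aromatic ring. In an ADME assay on HEp-2 cells (Homo sapiens) for cytotoxicity, read by MTT assay, with a stated time of 3 days (on this read-out lower numbers stand for higher toxicity in this test and higher numbers for lower toxicity in this test), compound 1 gives 75.2 ug/mL, the highest of the three numbers measured. Compound 2 `CC[C@@H](CCn1cncn1)c1ccc(C)cc1` is its mirror form at the chain carbon and gives 69.9 ug/mL; the step of a 1.1-fold lower number from compound 1 to compound 2 (0.03 log units; within the scatter) rests on the fact that compounds 1 and 2 differ only in the configuration as drawn alone. Compound 3 `CCCC[C@H](CCn1cncn1)c1ccc(Cl)cc1Cl` carries a butyl group and a dichloro aromatic ring and gives 13.4 ug/mL; it differs from compound 1 in more than one place, so its lower number cannot be tied to a single change.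

Compound 4 `Cc1ccc([C@@H](CCn2cncn2)Cc2ccccc2)cc1` is compound 1 with phenyl in place of methyl on a saturated chain carbon, two bonds along the chain from an aromatic carbon. Going by the values given here, none of the measured steps touches this position, and the only single-place step, from compound 1 to compound 2, lies within the scatter. The lower number of compound 3 is the only hint that adding more carbon to this chain may bring the number down in this assay. On that thin basis a moderate fall is expected, a 1.9-fold lower number from compound 1 to compound 4 (0.27 log units; within the scatter), for compound 4, with wide uncertainty. Compound 4 is therefore estimated at 40 ug/mL in this assay, within a range of 14 ug/mL to 95 ug/mL.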

Compound 4, half-maximal cytotoxic concentration: 83.3 ug/mL
The estimate for compound 4 lay 2.1-fold (0.32 log units) below the measured number; the range from low to high includes it.
By their numbers in this assay, from the lowest: compound 3; then compounds 2, 1 and 4 (each within the scatter of the next).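

In this assay the step from methyl to phenyl gives a 1.1-fold higher number from compound 1 to compound 4 (0.04 log units; within the scatter). This saturated chain carbon, two bonds along the chain from an aromatic carbon, therefore accepts a group of 6 heavy atoms in place of 1 heavy atom, including a six-membered aromatic ring, without a change that stands clear of the scatter. Adding carbon at this place does not by itself bring the number down, at least for phenyl, although nothing measured here accounts for this result.

Going by these compounds, it remains open whether other groups at this place would behave in the same way, for example an amine or a carboxylic acid, which would bring in atoms other than carbon. Going by these compounds alone, also open are the mirror form of compound 4 and which feature of compound 3 goes with its lower number, as its butyl group and dichloro aromatic ring appear together and no single-place step separates them.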